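Swapping one group on the carbonyl carbon of compound 2

The compounds below may be only part of what the source reports. "The series", "measured", "known", "first", "only" and "open" are said of these compounds alone.

Measured in a functional assay on CAKI-1 cells (Homo sapiens) for inhibition, read by sulforhodamine B assay, with a stated time of 48 h (a higher number here means a weaker inhibitor of growth, a lower number a stronger inhibitor of growth), so far:
- compound 1 (`COc1cc(-c2nn(-c3cccc(NC(=O)Nc4cc(C(F)(F)F)cc(C(F)(F)F)c4)c3)cc2-c2ccncc2)ccc1Cl`) gives 993 nM
- compound 2 (`COc1cc(-c2nn(-c3cccc(NC(=O)c4cccc(C(F)(F)F)c4)c3)cc2-c2ccncc2)ccc1Cl`) gives 2010 nM

Compound 2 has the higher of the two numbers, which makes it the weaker growth inhibitor of this pair, and its gap to compound 1 lies beyond the usual scatter. Compound 3 (`COc1cc(-c2nn(-c3cccc(NC(=O)Nc4ccc(Cl)c(C(F)(F)F)c4)c3)cc2-c2ccncc2)ccc1Cl`) differs from compound 2 in one place, with (4-chloro-3-(trifluoromethyl)phenyl)amino in place of 3-(trifluoromethyl)phenyl on a carbonyl carbon. Among the compounds with values here, no measured pair shows this change on its own, so any expectation is loose. A phenyl group joined through an amino nitrogen to that carbonyl carbon also occurs in compound 1 (993 nM) and compound 3 is therefore expected to land near that number. The step expected in this assay is a 2.0-fold lower number from compound 2 to compound 3 (0.30 log units; within the scatter) and would mean stronger inhibition of growth. Compound 3 is estimated at 1000 nM with a range of 400 nM to 2500 nM for repeat measurements.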

Compound 3, concentration for 50% growth inhibition: 992 nM
For compound 3 the middle estimate is 1.0-fold (0.00 log units) above the measured one; low and high end bracket the measured number.
By their numbers in this assay, from the lowest: compounds 3 and 1 (each within the scatter of the next); then compound 2.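

In this assay, within the data shown here, replacing 3-(trifluoromethyl)phenyl on the carbonyl carbon with (4-chloro-3-(trifluoromethyl)phenyl)amino gives a 2.0-fold lower number from compound 2 to compound 3 (0.31 log units; beyond the scatter), a modest gain in growth inhibition and the first direct comparison at this position. The entering group adds both an amino nitrogen and a chlorine, so this single step cannot separate what each contributes. Compound 3 and compound 1 lie within the scatter of each other, so their two differently substituted phenyl groups on the amino nitrogen cannot be ranked in this assay.

A compound carrying (3-(trifluoromethyl)phenyl)amino on the carbonyl carbon would show whether the amino nitrogen alone accounts for the step, and a methylene in that place would test the link further. No measurement shown explains the step.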